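Cyano to silyl-alkyne exchange on the shared core

The source may hold more compounds than are shown below. What is called first, only, known or untested is meant among the compounds shown, and "the series" means these compounds.

compound 1, `C[Si](C)(C)C#Cc1cc(-c2nc3cc(F)ccc3s2)ccc1N`: 210 nM
compound 2, `N#Cc1cc(-c2nc3ccc(F)cc3s2)ccc1N`: 320 nM

Both numbers come from a functional assay on MDA-MB-468 cells (Homo sapiens) for inhibition, with a stated time of 72 h; on this read-out higher numbers stand for weaker inhibition of growth and lower numbers for stronger inhibition of growth. Compound 2 has the higher of the two, but compound 1 lies within the scatter of it, so no order can be read. Compound 3, `C[Si](C)(C)C#Cc1cc(-c2nc3ccc(F)cc3s2)ccc1N`, is not yet measured. From compound 2 to compound 3 the change is a group of 6 heavy atoms (5 carbon, 1 silicon; no ring) in place of a group of 2 heavy atoms (1 carbon, 1 nitrogen; no ring), on an aromatic carbon. Within the data shown here, no measured pair shows this exact change. Compound 1 carries the same entering group on a core that differs only in the placement of its fluorine, and in this assay compound 1 gives 210 nM. The step of a 1.4-fold lower number from compound 2 to compound 3 (0.14 log units; within the scatter) is therefore expected to be small, toward stronger inhibition, and within the scatter. Compound 3 is expected to give 230 nM, with a range from 100 nM to 500 nM.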

Compound 3, concentration for 50% growth inhibition: 400 nM
For compound 3 the middle estimate is 1.7-fold (0.24 log units) below the measured one; low and high end bracket the measured number.
By their numbers in this assay, from the lowest: compounds 1, 2 and 3 (each within the scatter of the next).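

Replacing cyano with the silyl alkyne on the aromatic carbon ortho to an amino group gives a 1.3-fold higher number from compound 2 to compound 3 (0.10 log units; within the scatter) in this assay. At this position, then, the group of 6 heavy atoms and the cyano cannot be told apart in this read-out, although the entering group has no hydrogen-bond acceptor and the cyano has one. No measurement here bears on the reason for this. Still open, from the compounds shown here alone, is whether a carboxylic acid or an amine on this carbon would give a step beyond the scatter.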